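This account rests on a few compounds, and the source may have more. Where it says the series, first, only, none or still open, it means among the compounds named here.

Working notes on the series. Compound 1 `CC(C)N(Cc1cccc(OCCCCCC(=O)O)c1)C(=O)c1ccc(-c2cccc(C(F)(F)F)c2)cc1` and compound 2 `CCOC(=O)CCCCCOc1cccc(CN(C(=O)c2ccc(-c3ccc4ccccc4c3)cc2)C(C)C)c1` share a common core and differ in the aryl group and in the chain end. In an ADME assay on BJ cells (Homo sapiens) for cytotoxicity, read by CellTiter-Glo and resazurin assay, with a stated time of 72 h (a lower number here means that less compound is needed, a higher number that more compound is needed for the effect), compound 1 gives only a limit of the assay, > 26000 nM. Compound 2 also gives only a limit in this assay, > 26000 nM. So compound 2 stands at a limit and not at a number, as does the one other value recorded: both sit at the limit of > 26000 nM in this assay, at which 2 of the 2 values shown sit. No step between measured compounds can be read from this, and no cause is given for the limits. Compound 3 `CCOC(=O)CCCCCOc1cccc(CN(C(=O)c2ccc(-c3ccc4[nH]ccc4c3)cc2)C(C)C)c1` is the next entry, derived from compound 2 by a single change: 1H-indol-5-yl in place of naphthalen-2-yl on an aromatic carbon. With both measured compounds at the limit, the step that the limit leaves unreadable from compound 2 to compound 3 is expected to be none beyond the scatter. Compound 3 is estimated at 30000 nM, in a range from 15000 nM to 60000 nM, and is expected most likely to be reported again as a limit.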

Compound 3, half-maximal effective concentration: > 26000 nM
Compound 3: only a limit was reported (the forecaster's own chance of this, stated with the estimate: 85%); the middle value lies beyond the limit too.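

Among these compounds, no step from compound 2 to compound 3 can be read in this assay, as both give only a limit: the limit of > 26000 nM in this assay, at which 3 of the 3 values shown sit.
The compounds shown leave open whether in this assay any change in the aryl group or the chain end gives a number rather than a limit.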